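The source may hold more compounds than are shown below. What is called first, only, known or untested is meant among the compounds shown, and "the series" means these compounds.

Compound 1 `COC(=O)C1=C(C)NC(c2nccs2)=N[C@]1(C)c1ccc(F)cc1`: 178 ug/mL
Compound 2 `COC(=O)C1=C(C)NC(c2nccs2)=NC1(C)c1ccc(C#N)cc1`: 87 ug/mL
Compound 3 `COC(=O)C1=C(CN2CCC(O)CC2)NC(c2nccs2)=NC1(C)c1ccc(F)cc1`: 593 ug/mL

In a physicochemical assay for solubility, read by HPLC, in phosphate buffer, at pH 6.5 (on this read-out lower numbers stand for lower solubility and higher numbers for higher solubility), compound 3 stands highest of the three numbers; compound 1 gives 178 ug/mL and compound 2 gives 87 ug/mL, and both gaps to compound 3 lie beyond the scatter. Compound 4 `COC(=O)C1=C(COC(C(=O)O)C(F)(F)F)NC(c2nccs2)=NC1(C)c1ccc(F)cc1` has not yet been measured in this assay. It differs from compound 3 by a group of 9 heavy atoms (3 carbon, 3 oxygen, 3 fluorine; no ring) in place of a group of 7 heavy atoms (5 carbon, 1 nitrogen, 1 oxygen; one six-membered non-aromatic ring with 1 hetero atom), on a saturated chain carbon bound to a double-bonded ring carbon. Among the measured compounds shown here, no step between two measured compounds covers a change of this kind, so nothing measured here shows its size. The step of a 1.7-fold lower number from compound 3 to compound 4 (0.23 log units; within the scatter) is expected to be small, within the scatter, with no clear direction. Compound 4 is therefore estimated at 350 ug/mL, with a range from 90 ug/mL to 1400 ug/mL.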

Compound 4, solubility: > 649 ug/mL
Compound 4: only a limit was reported; the forecaster's own chance of this, stated with the estimate: 5%; at least 1.8-fold (0.26 log units) between middle value and limit.
By their numbers in this assay, from the lowest: compound 2; then compound 1; then compound 3. At a limit, above all of these: compound 4.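

Compound 4 is read only as a limit of the assay: the limit of > 649 ug/mL in this assay, at which 1 of the 4 values shown sits. In this assay the change gives an at least 1.0-fold higher number from compound 3 to compound 4 (0.03 log units; that floor lies within the scatter), so the step has a floor but no measured size. On a saturated chain carbon bound to a double-bonded ring carbon, the 4-hydroxypiperidin-1-yl group can thus give way to a group with no ring and no nitrogen without the reading falling below that of compound 3.

From the compounds shown here alone, how far compound 4 lies past its limit stays open. Also open, going by these compounds, is what an open-chain amine or a carboxylic acid without trifluoromethyl would read at this place.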